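Benzyl for Acetyl on the Ring Amine of Compound 2

The compounds below may be only part of what the source reports. "The series", "measured", "known", "first", "only" and "open" are said of these compounds alone.

Measured so far:
compound 1 `NC(=O)c1c(NC(=O)c2ccc(Oc3ccccc3)cc2)sc2c1CCN(Cc1ccccc1)C2` — 23.6%
compound 2 `CC(=O)N1CCc2c(sc(NC(=O)c3ccc(OCc4ccccc4)cc3)c2C(N)=O)C1` — 11.6%

Of the compounds shown here, two have been measured in an ADME assay on RAW264.7 cells (Mus musculus) for cytotoxicity, read by MTT assay, with a stated time of 48 h, tested at 50 uM; on this read-out higher numbers stand for more inhibition at the one concentration tested (going by the name of the read-out) and lower numbers for less inhibition. Compound 1 gives 23.6%, while compound 2 gives 11.6%, the lower of the two numbers; the gap from compound 2 up to compound 1 lies beyond the usual scatter of this assay.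

Compound 3 `NC(=O)c1c(NC(=O)c2ccc(OCc3ccccc3)cc2)sc2c1CCN(Cc1ccccc1)C2` has not yet been measured. It arises from compound 2 by a single change: benzyl in place of acetyl on an amine nitrogen in a ring. Among the compounds with values here, no step between measured compounds covers this change, so its size has to be judged from the two values at hand. Compound 1, which carries the same benzyl on its ring amine nitrogen, gives 23.6% in this assay, and on that basis the change is expected to raise inhibition in this assay rather than lower it, by a step of moderate size. Compound 3 is therefore estimated at 21%, within a range of 9% to 33%. The step this implies, a number 9.4 percentage points higher from compound 2 to compound 3 (within the scatter), is expected to sit somewhat beyond the scatter, though a result within it would not be surprising.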

Compound 3, a percentage reported as inhibition, at one concentration (the size of the read-out at that concentration, not a potency): 24%
Estimate against measurement, compound 3: 3 percentage points below; low and high end bracket the measured number.
By their numbers in this assay, from the lowest: compound 2; then compounds 1 and 3 (each within the scatter of the next).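

In this assay, benzyl in place of acetyl on the amine nitrogen in the ring gives a number 12.4 percentage points higher from compound 2 to compound 3 (beyond the scatter), so this position now has a direct step of its own, with nothing else in the molecule changed. Benzyl in place of phenyl on the oxygen on the aromatic ring gives a number 0.4 percentage points higher from compound 1 to compound 3 (within the scatter), so with benzyl on the ring nitrogen, this second change leaves no difference that can be told from the scatter, and the ring nitrogen is the only one of these two places where a change has been seen to shift the read-out. Nothing among the data at hand explains why the number moves with this change at the ring nitrogen.

On these data alone, only acetyl and benzyl have been compared at this nitrogen, so it remains open where a methyl, a longer alkyl chain or a benzoyl group there would fall relative to compound 2 and compound 3. As far as these compounds go, it is also open whether acetyl and benzyl would differ by a similar step with phenyl rather than benzyl on the oxygen.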